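This account rests on a few compounds, and the source may have more. Where it says the series, first, only, none or still open, it means among the compounds named here.

Measured compounds:
compound 1, `CCCCCCCCCCCCCCCCCCSC(=O)Nc1c(C)cccc1C`, which in an assay on microsomes from intestinal mucosa for inhibition of acyl-CoA:cholesterol acyltransferase (Oryctolagus cuniculus) (on this read-out lower numbers stand for stronger inhibition and higher numbers for weaker inhibition), gives only a limit, > 10000 nM
compound 2, `CCCCCCCC/C=C\CCCCCCCCNC(=O)Nc1ccccc1`, which in this assay gives only a limit, > 5000 nM
compound 3, `CCCCCCCC/C=C\CCCCCCCCNC(=O)Nc1ccc(Oc2ccccc2)cc1`, which in this assay gives only a limit, > 5000 nM

Compound 2 therefore stands at a limit, not a number, and the other two values are limits as well (the limit of > 10000 nM in this assay, at which 1 of the 3 values shown sits, (the limit of > 5000 nM in this assay, at which 2 of the 3 values shown sit)). Compound 4, `CCCCCCCC/C=C\CCCCCCCCNC(=O)Nc1c(Cl)cc(Cl)cc1Cl`, differs from compound 2 by 2,4,6-trichlorophenyl in place of phenyl on an amide-type nitrogen. Among the compounds with values here, the only measured step, a step that the two limits leave unreadable from compound 2 to compound 3, is unreadable, so no size or direction can be carried over to the new change. With no readable step to build on, the expected step is a step that the limit leaves unreadable from compound 2 to compound 4, taken as a placeholder rather than a prediction. Compound 4 is thus estimated at 8000 nM, within 1000 nM to 60000 nM, with a real chance that the assay again reports only a limit.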

Compound 4, half-maximal inhibitory concentration: 1200 nM
For compound 4 the middle estimate is 6.7-fold (0.82 log units) above the measured one, within the range that was stated.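

In this assay, 2,4,6-trichlorophenyl in place of phenyl on the amide-type nitrogen gives an at least 4.1-fold lower number from compound 2 to compound 4 (0.61 log units; beyond the scatter), so the number at this place does respond to a change on the aromatic ring; the step to compound 3 cannot be read and could not show this. Within the data shown here, compound 4 is also the only compound here with a number rather than a limit. Nothing shown here accounts for the lower number. From the compounds shown here alone, it remains open whether all three chlorines are needed, and whether methyl groups in their place on the same ring would give a similar number.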